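Swapping acetamido for hydroxymethyl at the glucagon receptor

This account rests on a few compounds, and the source may have more. Where it says the series, first, only, none or still open, it means among the compounds named here.

Measured so far:
compound 1, `CCCCCc1c(C(C)C)nc(C(C)C)c(CO)c1-c1ccccc1NC(C)=O`: 13%
compound 2, `CCCCCc1c(C(C)C)nc(C(C)C)c(CO)c1-c1ccc2c(c1)CCCC2`: 37%

Both were tested in an assay on CHO cells for inhibition of Glucagon receptor (Homo sapiens), tested at 20 uM; a higher number here means more inhibition at the concentration tested (going by the name of the read-out), a lower number less inhibition. Compound 1 gives 13%, while compound 2 gives 37%, so compound 1 stands lowest of the two numbers, with compound 2 higher by a margin beyond the scatter. Compound 3, `CCCCCc1c(C(C)C)nc(C(C)C)c(CO)c1-c1ccccc1CO`, has not yet been measured. It differs from compound 1 as follows: hydroxymethyl in place of acetamido on an aromatic carbon. Going by the values given here, no step between measured compounds that isolates such a change is available, so the expected step of a number 2 percentage points higher from compound 1 to compound 3 (within the scatter) is likely to stay within the scatter in either direction. Compound 3 is therefore expected to give about 15%, in a range from 3% to 32%.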

Compound 3, a percentage reported as inhibition, at one concentration (the size of the read-out at that concentration, not a potency): 44%
The estimate for compound 3 lay 29 percentage points below the measured number, outside the stated range (above it).
By their numbers in this assay, from the lowest: compound 1; then compounds 2 and 3 (each within the scatter of the next).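

In this assay, the place on the aromatic carbon ortho to a large group proves sensitive to what it carries: hydroxymethyl in place of acetamido gives a number 31 percentage points higher from compound 1 to compound 3 (beyond the scatter) as a large step. This happens although the two groups have the same counts of hydrogen-bond donors and acceptors, so those counts alone do not set the read-out at this place. Nothing available accounts for the size of this step.

As far as these compounds go, it remains open whether an amine, a carboxylic acid or a longer chain ending in hydroxyl would hold this level. A plain methyl group at the same place would show whether the oxygen of hydroxymethyl matters at all.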